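Alkyne to alkene, fluorine removed: a nucleoside pair

The compounds below may be only part of what the source reports. "The series", "measured", "known", "first", "only" and "open" are said of these compounds alone.

Compound 1 `Nc1ncnn2c([C@@H]3O[C@H](CO)[C@@H](O)[C@H]3O)cc(C#Cc3ccc(F)cc3)c12` was tested in a functional assay on HCT-116 cells (Homo sapiens) for antiproliferative activity, with a stated time of 72 h (a lower number here means a stronger inhibitor, a higher number a weaker inhibitor), and gave only a limit of the assay, > 100000 nM, so its true number is not known. Compound 2 `Nc1ncnn2c([C@@H]3O[C@H](CO)[C@@H](O)[C@H]3O)cc(C#Cc3ccccc3)c12` gives 46900 nM in this assay. The step of an at least 2.1-fold lower number from compound 1 to compound 2 (0.32 log units; beyond the scatter) rests on (the limit of > 100000 nM in this assay, at which 1 of the 2 values shown sits), so its size is only a lower bound.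

Compound 3 `Nc1ncnn2c([C@@H]3O[C@H](CO)[C@@H](O)[C@H]3O)cc(/C=C/c3ccccc3)c12` carries a different group on the shared core: 2-phenylethenyl in place of 2-(4-fluorophenyl)ethynyl on an aromatic carbon. Part of this change, the loss of fluoro, matches the measured step from compound 1 to compound 2, which was at least modest in the direction of a lower number. Among the measured compounds shown here, the other part, the double bond in place of the triple bond, has no measured counterpart here. Compound 3 is therefore expected to land near compound 2, with the step of an at least 2.2-fold lower number from compound 1 to compound 3 (0.34 log units; beyond the scatter) estimated from the limit, giving an estimate of 45000 nM within 12000 nM to 150000 nM.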

Compound 3, half-maximal inhibitory concentration: 4800 nM
Compound 3: middle estimate off by 9.4-fold (0.97 log units), on the high side; measured number below the stated range.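

Replacing the triple bond with a double bond, with the unsubstituted phenyl ring kept, has a clear effect of its own in this assay, giving a 9.8-fold lower number from compound 2 to compound 3 (0.99 log units; beyond the scatter). At this aromatic carbon, then, the kind of carbon-carbon bond in the side group affects the antiproliferative read-out, and the fluoro difference alone does not account for the whole change. Compound 1 stands at a limit of the assay, so the full change, an at least 20-fold lower number from compound 1 to compound 3 (1.31 log units; beyond the scatter), is known only as a lower bound: the limit of > 100000 nM in this assay, at which 1 of the 3 values shown sits.

The compounds shown leave open whether a fluoro on the phenyl ring of the 2-phenylethenyl group would also give a higher number. They also leave open how a 2-phenylethyl group, with a single bond in that place, or an amine on the phenyl ring would behave at this position.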